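Thioester acyl extension in the pyridyl-pyrazole amide series

This account rests on a few compounds, and the source may have more. Where it says the series, first, only, none or still open, it means among the compounds named here.

Compound 2 `CC(=O)SCCCCCCNC(=O)c1cc(-c2ccncc2)n[nH]1` gives 18000 nM in a functional assay on A549 cells (Homo sapiens) for inhibition, read by MTT assay, with a stated time of 96 h (a lower number here means a stronger inhibitor of growth, a higher number a weaker inhibitor of growth), and stands highest of the two numbers on hand, though its nearest neighbour, compound 1 `C=CCOC(=O)SCCCCCCNC(=O)c1cc(-c2ccncc2)n[nH]1`, gives 15200 nM and the gap is within the scatter. Compound 3 `CCCC(=O)SCCCCCCNC(=O)c1cc(-c2ccncc2)n[nH]1` carries ethyl in place of hydrogen on a saturated chain carbon bound to a carbonyl carbon, which cut one bond further out reads acetyl to propylcarbonyl. Among the measured compounds shown here, the one step that bears on this, a 1.2-fold higher number from compound 1 to compound 2 (0.07 log units; within the scatter), also altered the group on that carbonyl carbon and stayed within the scatter, so no step beyond the scatter is expected here. Compound 3 is therefore estimated at 16000 nM, range 8000 nM to 32000 nM, an expected step of a 1.1-fold lower number from compound 2 to compound 3 (0.05 log units; within the scatter).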

Compound 3, concentration for 50% growth inhibition: 15100 nM
For compound 3 the middle estimate is 1.1-fold (0.03 log units) above the measured one, and the stated range covers the measured number.
By their numbers in this assay, from the lowest: compounds 3, 1 and 2 (each within the scatter of the next).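

Acetyl to propylcarbonyl on the thioester gives a 1.2-fold lower number from compound 2 to compound 3 (0.08 log units; within the scatter) in this assay and shows that ethyl in place of hydrogen at this saturated chain carbon leaves the number within the scatter. Propyl in place of allyloxy on the carbonyl carbon gives a 1.0-fold lower number from compound 1 to compound 3 (0.00 log units; within the scatter) and places all three acyl groups shown within the scatter of one another. No evidence on hand bears on this result.

On these data alone, whether an amine, a carboxylic acid or a longer chain on this carbonyl carbon would give a step beyond the scatter remains open.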